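The compounds below may be only part of what the source reports. "The series", "measured", "known", "first", "only" and "open" are said of these compounds alone.

Compound 1 `COc1ccc(C[C@H]2COC(=O)[C@@H]2Cc2ccc(OC(=O)CCC(=O)N3CCCC3)c(OC)c2)cc1OC`: 201000 nM
Compound 2 `COc1ccc(C[C@H]2COC(=O)[C@@H]2Cc2ccc(OCc3cn(Cc4ccc(Cl)cc4)nn3)c(OC)c2)cc1OC`: 242000 nM
Compound 3 `CCN1CCN(C(=O)CCC(=O)Oc2ccc(C[C@H]3C(=O)OC[C@@H]3Cc3ccc(OC)c(OC)c3)cc2OC)CC1`: 190000 nM

Of the compounds shown here, three sharing one core have been measured in an ADME assay on HeLa cells (Homo sapiens) for cytotoxicity, read by MTT assay (on this read-out higher numbers stand for weaker inhibition and lower numbers for stronger inhibition), and all three give numbers that lie within the usual scatter of one another. Compound 1 sits in the middle of this narrow group: compound 3 gives 190000 nM, and compound 2 gives 242000 nM, so nothing separates compound 1 from either of them beyond the scatter. For the measured compounds named here, the only step that changes a single place, a 1.1-fold lower number from compound 1 to compound 3 (0.02 log units; within the scatter), swaps one amine for another on a carbonyl carbon and leaves the number unchanged in practice.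

Compound 4 `COc1ccc(C[C@H]2COC(=O)[C@@H]2Cc2ccc(OCC(=O)N3CCOCC3)c(OC)c2)cc1OC` is the new compound. Its change from compound 1 is a group of 9 heavy atoms (6 carbon, 1 nitrogen, 2 oxygen; one six-membered non-aromatic ring with 2 hetero atoms) in place of a group of 11 heavy atoms (8 carbon, 1 nitrogen, 2 oxygen; one five-membered non-aromatic ring with 1 hetero atom), on an oxygen on an aromatic ring

This change again alters the group on the oxygen on an aromatic ring while keeping the shared core. Going by the values given here, the one step that bears on it, from compound 1 to compound 3, stayed within the scatter, and compound 2, with a quite different group on that same oxygen, gives a number in the same range. On this basis no step beyond the scatter is expected in this assay, in either direction. The expected step is a 1.0-fold lower number from compound 1 to compound 4 (0.00 log units; within the scatter). Compound 4 is estimated at 200000 nM, with a range from 120000 nM to 330000 nM.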

Compound 4, half-maximal inhibitory concentration: >= 600000 nM
Compound 4: a limit, no number; the forecaster's own chance of this, stated with the estimate: 20%; middle value at least 3.0-fold (0.47 log units) from the limit.
By their numbers in this assay, from the lowest: compounds 3, 1 and 2 (each within the scatter of the next). At a limit, above all of these: compound 4.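

In this assay, for the compounds shown here, the earlier compounds showed only small differences, and the one step between them that changes a single place, a 1.1-fold lower number from compound 1 to compound 3 (0.02 log units; within the scatter), altered only the amine on a carbonyl carbon. Going by these compounds alone, replacing the whole group on an oxygen on an aromatic ring with ((morpholin-4-yl)carbonyl)methyl gives the first step beyond the scatter, an at least 2.9-fold higher number from compound 1 to compound 4 (0.47 log units; beyond the scatter), so this position can shift the number towards weaker inhibition in this assay. The result for compound 4 is a limit of the assay and not a number: the limit of >= 600000 nM in this assay, at which 1 of the 4 values shown sits.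

The group that enters differs from the one that leaves in both its chain and its ring, and the compounds shown cannot tell which of these differences matters for the step. Going by these compounds, it remains open whether a morpholin-4-yl ring on the longer chain of compound 1, or a piperidin-1-yl ring or a carboxylic acid on the shorter chain of compound 4, would give a number as high as this limit.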